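Vero cell cytotoxicity notes on a shared-core series

This account rests on a few compounds, and the source may have more. Where it says the series, first, only, none or still open, it means among the compounds named here.

Compound 1 `CCCCOC(=O)Nc1cc2nc(C3CCCCC3)[nH]c2cc1N(C)C`, compound 2 `CN(C)c1cc2[nH]c(C3CCCCC3)nc2cc1NC(=O)OCc1ccccc1` and compound 3 `O=C(NCc1ccccc1)Nc1cc2nc(C3CCCCC3)[nH]c2cc1N1CCCC1` have been run in an ADME assay on Vero cells (Chlorocebus sabaeus) for cytotoxicity, read by resazurin assay, with a stated time of 3 days; a higher number here means a weaker inhibitor, a lower number a stronger inhibitor. In this assay compound 1 gives only a limit, > 100 ug/mL. Compound 2 likewise gives only a limit in this assay, > 100 ug/mL. For compound 3 the result in this assay is again a limit, > 100 ug/mL. The difference between compound 2 and compound 1 is propyl in place of phenyl on a saturated chain carbon bound to an oxygen next to a carbonyl group, and the step that the two limits leave unreadable from compound 2 to compound 1 cannot be sized because of the limit of > 100 ug/mL in this assay, at which 3 of the 3 values shown sit. The difference between the cores of compound 2 and compound 3 is not broken down here.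

Compound 4 `CCCCNC(=O)Nc1cc2nc(C3CCCCC3)[nH]c2cc1N1CCCC1` has not yet been measured. It differs from compound 3 by propyl in place of phenyl on a saturated chain carbon bound to an amide-type nitrogen. This is the same kind of change as from compound 2 to compound 1, though there the place is a saturated chain carbon bound to an oxygen next to a carbonyl group, whereas here it is a saturated chain carbon bound to an amide-type nitrogen. In this assay the expected step is a step that the limit leaves unreadable from compound 3 to compound 4, which rests on a step that the two limits leave unreadable from compound 2 to compound 1 and on (the limit of > 100 ug/mL in this assay, at which 3 of the 3 values shown sit). Compound 4 is estimated at 150 ug/mL in this assay, between 70 ug/mL and 300 ug/mL, most likely reported once more only as a limit.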

Compound 4, half-maximal inhibitory concentration: > 100 ug/mL
Compound 4 ended at the assay's limit (the forecaster's own chance of this, stated with the estimate: 85%); the middle value is on the limit's open side.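

In this assay no new step can be read between compound 3 and compound 4, because both sit at the same limit: the limit of > 100 ug/mL in this assay, at which 4 of the 4 values shown sit.

The compounds shown leave open how compounds 1 to 4 rank against one another, and what size of step, if any, propyl in place of phenyl gives on a saturated chain carbon bound to an amide-type nitrogen.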